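Acetylation of the ring hydroxyl in a diterpenoid lactone series

The source may hold more compounds than are shown below. What is called first, only, known or untested is meant among the compounds shown, and "the series" means these compounds.

Three compounds of the series have been run in a functional assay on Col2 cells (Homo sapiens) for cytotoxicity, read by sulforhodamine B assay; a higher number here means that more compound is needed for the effect, a lower number that less compound is needed. Compound 3 `C=C1CC[C@@H]2[C@](C)(CO)[C@H](OC(C)=O)CC[C@@]2(C)[C@@H]1C/C=C1/C(=O)OC[C@H]1OC(C)=O` gives 10.2 uM and compound 1 `C=C1CC[C@@H]2[C@](C)(COC(C)=O)[C@H](OC(C)=O)CC[C@@]2(C)[C@@H]1C/C=C1/C(=O)OC[C@H]1OC(C)=O` gives 10.8 uM; the two differ by acetyl in place of hydrogen on an oxygen on a saturated carbon, and the step is a 1.1-fold higher number from compound 3 to compound 1 (0.02 log units; within the scatter). Compound 2 `C=C1CC[C@@H]2[C@](C)(CO[Si](c3ccccc3)(c3ccccc3)C(C)(C)C)[C@H](OC(C)=O)CC[C@@]2(C)[C@@H]1C/C=C1/C(=O)OC[C@H]1O` gives 3.8 uM, the lowest number of the three, beyond the scatter from both others. The difference between the core of compound 2 and the core of compound 3 is not broken down here.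

Compound 4 `C=C1CC[C@@H]2[C@](C)(CO[Si](c3ccccc3)(c3ccccc3)C(C)(C)C)[C@H](OC(C)=O)CC[C@@]2(C)[C@@H]1C/C=C1/C(=O)OC[C@H]1OC(C)=O` awaits measurement in this assay. It differs from compound 2 by acetyl in place of hydrogen on an oxygen on a saturated carbon. This is the same kind of change as that from compound 3 to compound 1, though around the place the other neighbour of the saturated carbon is a saturated ring carbon in compound 2, whereas in compound 3 it is a saturated chain carbon. Since the earlier step, from compound 3 to compound 1, stayed within the scatter at a 1.1-fold higher number from compound 3 to compound 1 (0.02 log units; within the scatter), a comparably small step is expected from compound 2 to compound 4, a 1.1-fold higher number from compound 2 to compound 4 (0.04 log units; within the scatter). Compound 4 is therefore estimated at 4.2 uM, most likely between 2 uM and 9 uM.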

Compound 4, concentration for half-maximal effect: 12.3 uM
Beside the measured number, compound 4's estimate is 2.9-fold (0.47 log units) below it, and the stated range ends below it.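

Hydroxy to acetoxy gives a 3.2-fold higher number from compound 2 to compound 4 (0.51 log units; beyond the scatter) in this assay, so this change cannot be carried from one core to another in the series at a fixed size. Set beside the earlier step, the same change differs between the two cores: the same change on two cores in this assay, a 1.1-fold higher number (0.02 log units; within the scatter) from compound 3 to compound 1 and a 3.2-fold higher number (0.51 log units; beyond the scatter) from compound 2 to compound 4, 3.1-fold (0.49 log units) apart, beyond the scatter of two such steps. This shows only that the size of the step depends on its setting in these two pairs; it does not show which feature is responsible, since the acetyl enters on an oxygen on a saturated carbon whose other neighbour is a saturated ring carbon in one step and a saturated chain carbon in the other, and the cores differ as well.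

Two pairs give no rule for other cores in the series, and the separate contributions of the core and of the place of acetylation remain unresolved. Also open, going by these compounds, is how a longer acyl chain or an amine-bearing acyl group on the same oxygen would compare with acetyl.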